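The compounds below may be only part of what the source reports. "The series", "measured", "known", "first", "only" and "open" are said of these compounds alone.

Measured compounds:
Compound 1, `CCCC/N=C/c1cc2cc(C)ccc2[nH]c1=O`: 3560000 nM
Compound 2, `Cc1ccc2[nH]c(=O)c(/C=N/Nc3ccccc3)cc2c1`: 1470000 nM
Compound 3, `CCCC/N=C/c1cc2ccccc2[nH]c1=O`: 7680000 nM

Three compounds were tested in a functional assay, read by spectrophotometry, with a stated time of 1 h; on this read-out higher numbers stand for weaker inhibition and lower numbers for stronger inhibition. Compound 1, `CCCC/N=C/c1cc2cc(C)ccc2[nH]c1=O`, gives 3560000 nM. Compound 2, `Cc1ccc2[nH]c(=O)c(/C=N/Nc3ccccc3)cc2c1`, gives 1470000 nM, the lowest of the three numbers; its core differs from that of compound 1 by anilino in place of butyl on a double-bonded nitrogen, and the step is a 2.4-fold lower number from compound 1 to compound 2 (0.38 log units; beyond the scatter). Compound 3, `CCCC/N=C/c1cc2ccccc2[nH]c1=O`, gives 7680000 nM, the highest of the three; it differs from compound 1 by hydrogen in place of methyl on an aromatic carbon, and the step is a 2.2-fold higher number from compound 1 to compound 3 (0.33 log units; beyond the scatter). Between compound 2 and compound 3 no single change is shown, and the two values only show a gap between the lowest and highest numbers.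

The compound still to be measured is compound 4, `O=c1[nH]c2ccccc2cc1/C=N/Nc1ccccc1`. It differs from compound 2 by hydrogen in place of methyl on an aromatic carbon. Going by the values given here, this is the same change as the one from compound 1 to compound 3, made at the same place, only on the core of compound 2 rather than that of compound 1. With one earlier example, the expectation rests on that single step. Compound 4 is therefore expected to give about 3200000 nM in this assay, with a likely range from 1500000 nM to 7000000 nM. Among the compounds with values here, the expected step here is a 2.2-fold higher number from compound 2 to compound 4 (0.34 log units; beyond the scatter), chosen because a 2.2-fold higher number from compound 1 to compound 3 (0.33 log units; beyond the scatter) is the only guide available.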

Compound 4, half-maximal inhibitory concentration: 1000000 nM
Compound 4: the middle estimate sits 3.2-fold (0.51 log units) above what was measured; measured number outside the range, below it.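

In this assay, hydrogen in place of methyl on the aromatic carbon gives a 1.5-fold lower number from compound 2 to compound 4 (0.17 log units; within the scatter), so on this core the change leaves no difference that can be told from ordinary repeat variation. Set beside the earlier example, the same change does not carry over from one core to the other with the same size: the same change on two cores in this assay, a 2.2-fold higher number (0.33 log units; beyond the scatter) from compound 1 to compound 3 and a 1.5-fold lower number (0.17 log units; within the scatter) from compound 2 to compound 4, 3.2-fold (0.50 log units) apart, beyond the scatter of two such steps This shows that, across these four compounds, the step seen with butyl on the double-bonded nitrogen cannot be taken as a guide to the step with anilino there, but with only one pair on each core it does not show why the two differ or how the change would behave on a third core.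

As far as these compounds go, it remains open whether the methyl matters with other groups on the double-bonded nitrogen, such as a longer chain, a benzyl group or an anilino ring carrying a chlorine. From the compounds shown here alone, it is also open whether a group other than methyl at the same aromatic carbon, such as a methoxy group or a chlorine, would give a step that holds on both cores.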